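Permeability at the carbonyl end: from cyclopropyl to pyrrolidine

The source may hold more compounds than are shown below. What is called first, only, known or untested is meant among the compounds shown, and "the series" means these compounds.

Measured so far:
- compound 1, `Cn1cncc1CN1CC(N(CC2CCN(C(=O)N3CCCCC3)CC2)S(=O)(=O)c2ccccn2)Cc2cc(C#N)ccc21`: 0.6 10^-6 cm/s
- compound 2, `CC(=O)N1CCC(CN(C2Cc3cc(C#N)ccc3N(Cc3cncn3C)C2)S(=O)(=O)c2ccccn2)CC1`: 0.5 10^-6 cm/s
- compound 3, `Cn1cncc1CN1CC(N(CC2CCN(C(=O)C3CC3)CC2)S(=O)(=O)c2ccccn2)Cc2cc(C#N)ccc21`: 0.5 10^-6 cm/s

All three values come from an ADME assay on Caco-2 cells (Homo sapiens) for permeability, in the apical to basolateral direction; a lower number here means that the compound crosses the layer more slowly, a higher number that the compound crosses the layer faster. In this assay compound 3 gives 0.5 10^-6 cm/s, level with compound 2 at the digits shown; together they hold the lowest numbers of the three. Its furthest neighbour is compound 1: the step of a 1.2-fold lower number from compound 1 to compound 3 (0.08 log units; within the scatter) is within the scatter, as is no change at the digits printed from compound 2 to compound 3 (within the scatter).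

Compound 4, `Cn1cncc1CN1CC(N(CC2CCN(C(=O)N3CCCC3)CC2)S(=O)(=O)c2ccccn2)Cc2cc(C#N)ccc21`, carries a single change from compound 3: pyrrolidin-1-yl in place of cyclopropyl on a carbonyl carbon.

Within the data shown here, two measured steps bear on this change, since both alter the group on the same carbonyl carbon. The step of a 1.2-fold lower number from compound 1 to compound 2 (0.08 log units; within the scatter) swaps a ring amine for a methyl and stays within the scatter; a 1.2-fold lower number from compound 1 to compound 3 (0.08 log units; within the scatter) swaps the same ring amine for a cyclopropyl and also stays within the scatter. Compound 4 brings a ring amine back, closer in kind to compound 1 than compound 3 is. A step of no more than the scatter is therefore expected, in no particular direction, a 1.1-fold higher number from compound 3 to compound 4 (0.04 log units; within the scatter).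

On that basis compound 4 is estimated at 0.55 10^-6 cm/s, in a range from 0.3 10^-6 cm/s to 1.1 10^-6 cm/s.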

Compound 4, apparent permeability: 0.6 10^-6 cm/s
Compound 4: middle estimate off by 1.1-fold (0.04 log units), on the low side, and the stated range covers the measured number.
By their numbers in this assay, from the lowest: compounds 2, 3, 1 and 4 (each within the scatter of the next).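

With pyrrolidin-1-yl on the carbonyl carbon, this position now carries four different groups, and in this assay every pair among the four stays within the scatter, including the three new comparisons (a 1.2-fold higher number from compound 3 to compound 4 (0.08 log units; within the scatter); a 1.2-fold higher number from compound 2 to compound 4 (0.08 log units; within the scatter); no change at the digits printed from compound 1 to compound 4 (within the scatter)). Two ring amines, pyrrolidin-1-yl and piperidin-1-yl, therefore cannot be told apart from two carbon groups, methyl and cyclopropyl, by this measurement, and swapping one ring amine for the other adds nothing beyond the scatter. No measurement at hand offers a reason for this flat picture.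

Going by these compounds, it remains open whether any group on this carbonyl carbon can move the number beyond the scatter, for instance a carboxylic acid, a primary amine or a longer chain ending in a hydroxyl group. On these data alone, whether a change in the shared core would matter more than a change at this carbonyl also stays open, as all four compounds carry that core unchanged.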